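A few compounds are considered here, and "the series" means these few. Any claim that something is new, unique, unknown or untested is made for them only; others in the source may bear on it.

Compound 1, `CC(C)[C@H](NC(=O)COc1cccc2ccccc12)C(=O)N[C@@H](CC(=O)O)C(=O)CSC1=NCCS1`, is the starting point of this account. In a functional assay on Jurkat cells (Homo sapiens) for inhibition (on this read-out higher numbers stand for weaker inhibition and lower numbers for stronger inhibition), compound 1 gives > 200000 nM, which is a limit of the assay rather than a measured number, so its position among the compounds shown is known only as a limit. For the measured compounds named here, compound 2, `CC(C)[C@H](NC(=O)COc1cccc2ccccc12)C(=O)N[C@@H](CC(=O)O)C(=O)CSc1nnnn1-c1ccccc1`, is the one measured neighbour: in this assay compound 2 gives 153000 nM. Going by the values given here, the step between the two is an at least 1.3-fold lower number from compound 1 to compound 2 (0.11 log units; that floor lies within the scatter); it rests on the limit of > 200000 nM in this assay, at which 1 of the 2 values shown sits, and is the only measured step available here.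

Compound 3, `CC(C)[C@H](NC(=O)COc1cccc2ccccc12)C(=O)N[C@@H](CC(=O)O)C(=O)COn1nnc2ccccc21`, is the unmeasured compound of the piece. Its change from compound 1 is a group of 10 heavy atoms (6 carbon, 3 nitrogen, 1 oxygen; one five-membered aromatic ring with 3 hetero atoms, one six-membered aromatic ring of carbon only) in place of a group of 6 heavy atoms (3 carbon, 1 nitrogen, 2 sulfur; one five-membered non-aromatic ring with 2 hetero atoms), on a saturated chain carbon bound to a carbonyl carbon. Among the compounds with values here, no measured step shares this change; the one step on record alters the group on the sulfur and stays within the scatter, so it gives no direction for what happens when the whole sulfur-bearing group is exchanged on the chain carbon. With so little to lean on, compound 3 is expected to show an at least 4.0-fold lower number from compound 1 to compound 3 (0.60 log units; beyond the scatter), leaning towards a lower number while allowing for another limit. The estimate for compound 3 in this assay is therefore 50000 nM, with a range from 5000 nM to 200000 nM.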

Compound 3, half-maximal inhibitory concentration: > 200000 nM
Compound 3 ended at the assay's limit (the forecaster's own chance of this, stated with the estimate: 30%); at least 4.0-fold (0.60 log units) between middle value and limit.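

Exchanging the whole sulfur-bearing group on a saturated chain carbon bound to a carbonyl carbon for the group of 10 heavy atoms does not bring the read-out in this assay clear of the limit: compound 3 gives > 200000 nM, which is a limit and not a number. For the compounds shown here, the only comparison that can be read is an at least 1.3-fold higher number from compound 2 to compound 3 (0.11 log units; that floor lies within the scatter), so the shift from the sulfur-linked group of 12 heavy atoms to the oxygen-bearing group of 10 heavy atoms shows no change beyond the scatter, while the steps that rest on two limits cannot be read. What this position can show in this assay is therefore restricted by the limit itself: the limit of > 200000 nM in this assay, at which 2 of the 3 values shown sit.

From the compounds shown here alone, it remains open whether a phenoxy group or an amine on this saturated chain carbon would give a value clear of the limit. Also open, going by these compounds, is whether a longer chain on the sulfur would move the number in this assay beyond the scatter from compound 2.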